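Ring stereocentre inversion from compound 1 to compound 4

This account rests on a few compounds, and the source may have more. Where it says the series, first, only, none or still open, it means among the compounds named here.

Measured so far, in an ADME assay on microsomes from liver (Mus musculus) for metabolic stability; on this read-out lower numbers stand for a shorter-lived compound and higher numbers for a longer-lived compound:
compound 1 `CCCO[C@@H]1O[C@H](CNC(=O)c2ccc(S(N)(=O)=O)cc2)[C@@H](O)[C@H](O)[C@@H]1O`: 64.5 h
compound 2 `CCO[C@@H]1O[C@H](CNC(=O)c2ccc(S(N)(=O)=O)cc2)[C@@H](O)[C@H](O)[C@H]1N`: 58.6 h
compound 3 `CCO[C@@H]1O[C@H](CNC(=O)c2ccc(S(N)(=O)=O)cc2)[C@H](O)[C@H](O)[C@H]1O`: 61.1 h

Compound 1 holds the highest of the three numbers in this assay, yet its gaps to compound 3 and to compound 2 both lie within the usual scatter, so the three compounds are not separated by these data.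

Compound 4 `CCCO[C@@H]1O[C@H](CNC(=O)c2ccc(S(N)(=O)=O)cc2)[C@@H](O)[C@H](O)[C@H]1O` is not yet measured. Relative to compound 1: the two compounds have the same atoms and bonds and differ only in configuration as drawn: 1 of 5 stereo elements differ; a stereocentre at a saturated ring carbon is drawn S in compound 1 and R in compound 4

Among the measured compounds shown here, no pair of measured compounds isolates this kind of change, and the three values so far sit close together. The expectation is therefore no step beyond the scatter, in either direction: the estimated change a 1.1-fold lower number from compound 1 to compound 4 (0.03 log units; within the scatter) is small. Compound 4 is expected to give about 60 h, within 35 h to 100 h.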

Compound 4, half-life: 60 h
Compound 4: middle estimate and measured number agree at the digits printed, within the range that was stated.
By their numbers in this assay, from the lowest: compounds 2, 4, 3 and 1 (each within the scatter of the next).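

In this assay, the change at this saturated ring carbon, S in compound 1 and R in compound 4, gives a 1.1-fold lower number from compound 1 to compound 4 (0.03 log units; within the scatter) and so leaves the half-life unresolved from the parent. This is the only pair shown that isolates one change, so the reading for this stereocentre is clean: the fact that compounds 1 and 4 differ only in the configuration as drawn. At this position, inversion therefore produces no step beyond the scatter in this propyl series.

Going by these compounds, whether inversion at the other ring stereocentres behaves alike stays open, as does whether a longer chain in place of the propyl group would keep the half-life in this range.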